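Swapping phenylethenyl for dimethylaminophenyl on the shared core

The compounds below may be only part of what the source reports. "The series", "measured", "known", "first", "only" and "open" are said of these compounds alone.

Measured compounds:
Compound 1, `O=C1N=C(C2C(=O)c3ccccc3C2=O)CC(c2ccccc2)N1`: 11%
Compound 2, `O=C1N=C(C2C(=O)c3ccccc3C2=O)CC(/C=C/c2ccccc2)N1`: 16%

Among the measured compounds shown here, in a functional assay on the whole organism for inhibition, with Rattus norvegicus as the target, read by paw edema, with stated times of 30 min and 4 h, at a dose of 10 mg/kg by the oral route (a higher number here means more inhibition at the dose given (going by the name of the read-out), a lower number less inhibition), compound 2 holds the higher of the two numbers, but the only measured step, a number 5 percentage points higher from compound 1 to compound 2 (within the scatter), lies within the scatter, so the two numbers can only be called level. Compound 3, `CN(C)c1ccc(C2CC(C3C(=O)c4ccccc4C3=O)=NC(=O)N2)cc1`, differs from compound 2 by 4-(dimethylamino)phenyl in place of 2-phenylethenyl on a saturated ring carbon. For the measured compounds named here, no measured step covers this change; the one step known is small. The step of a number 3 percentage points lower from compound 2 to compound 3 (within the scatter) is therefore expected to stay within the scatter. For compound 3 the estimate is 13%, with a range from 2% to 26%.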

Compound 3, a percentage reported as inhibition, in the whole organism at one dose (the size of the read-out at that dose, not a potency): 16%
Estimate against measurement, compound 3: 3 percentage points below; the measured number falls inside the stated range.
By their numbers in this assay, from the lowest: compounds 1, 2 and 3 (each within the scatter of the next).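

In this assay the exchange of 2-phenylethenyl for 4-(dimethylamino)phenyl gives no change at the digits printed from compound 2 to compound 3 (within the scatter) and the dimethylamino group on the aromatic carbon gives a number 5 percentage points higher from compound 1 to compound 3 (within the scatter) as its step. This saturated ring carbon has now carried three different groups, one with a nitrogen, and all three numbers remain level. No supporting measurement is available to explain this flat result.

On these data alone, whether a carboxylic acid on the aromatic ring would move the number beyond the scatter remains open. The same question stands for a simple amine or a longer chain on the saturated ring carbon.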